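The compounds below may be only part of what the source reports. "The series", "measured", "known", "first", "only" and "open" are said of these compounds alone.

Compound 1 `CC(C)OC(=O)C1=CN(C(=O)c2ccc(C#N)cc2)CC(C)(C)c2cc(C#N)[nH]c21`: 116%
Compound 2 `CC(C)OC(=O)C1CN(C(=O)c2cccc(Cl)c2)CC(C)(C)c2cc(C#N)[nH]c21`: 103%
Compound 3 `CC(C)OC(=O)C1CN(C(=O)C2CCCCC2)CC(C)(C)c2cc(C#N)[nH]c21`: 127%

In an assay on HEK293 cells for agonist activity at Bile acid receptor (Homo sapiens), read by a luciferase reporter (on this read-out higher numbers stand for larger maximal responses and lower numbers for smaller maximal responses), compound 1 stands second highest of the three, with compound 3 above it and compound 2 below it, both gaps beyond the usual scatter. Compound 4 `CC(C)OC(=O)C1=CN(C(=O)C2CCCCC2)CC(C)(C)c2cc(C#N)[nH]c21` is derived from compound 1 by the change (cyclohexyl in place of 4-cyanophenyl on a carbonyl carbon). Within the data shown here, one measured step bears on this: a number 24 percentage points higher from compound 2 to compound 3 (beyond the scatter), where cyclohexyl likewise replaced an aryl group on the same carbonyl carbon, though that aryl was 3-chlorophenyl and the shared core of compounds 2 and 3 differs from that of compound 1. On this basis a modest rise is expected, a number 12 percentage points higher from compound 1 to compound 4 (beyond the scatter). Compound 4 is therefore estimated at 128%, within a range of 108% to 148%.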

Compound 4, largest response reached (reported as efficacy), in percent of the reference or control that the assay uses: 124%
Compound 4: middle estimate off by 4 percentage points, on the high side, and the stated range covers the measured number.
By their numbers in this assay, from the lowest: compound 2; then compounds 1, 4 and 3 (each within the scatter of the next, the first and the last beyond it).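

In this assay, a number 8 percentage points higher from compound 1 to compound 4 (within the scatter), so on this carbonyl carbon, in the core of compound 1, cyclohexyl in place of 4-cyanophenyl gives no step beyond the scatter. The earlier step, a number 24 percentage points higher from compound 2 to compound 3 (beyond the scatter), involved 3-chlorophenyl and a different core, so swapping an aryl group for cyclohexyl does not give a step beyond the scatter in every case shown. Nothing available explains this difference. The compounds shown leave open whether the aryl group or the core separates the two steps, and how an unsubstituted phenyl or a piperidine on this carbonyl carbon would read.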